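A Benzyl in Place of Methyl on the Piperidine

A few compounds are considered here, and "the series" means these few. Any claim that something is new, unique, unknown or untested is made for them only; others in the source may bear on it.

In a functional assay on DLD-1 cells (Homo sapiens) for antiproliferative activity, read by CellTiter-Glo, with a stated time of 72 h (a higher number here means a weaker inhibitor, a lower number a stronger inhibitor), three compounds have been measured:
Compound 1 `Cc1cc(C)c(S(=O)(=O)N2CCC(N3CCC(C)CC3)CC2)c(C)c1`: compound 1 gives 0.03 nM.
Compound 2 `Cc1cc(C)c(S(=O)(=O)N2CCC(c3ccccc3)CC2)c(C)c1`: compound 2 gives > 5000 nM, which is a limit of the assay and not a number.
Compound 3 `Cc1cc(C)c(S(=O)(=O)N2CCC(N3CC(C)CC(C)C3)CC2)c(C)c1`: compound 3 gives 17 nM.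

Compound 1 stands lowest of the two numbers; its nearest neighbour is compound 3, and the step of a 570-fold higher number from compound 1 to compound 3 (2.75 log units; beyond the scatter). Compound 2 sits at the limit of > 5000 nM in this assay, at which 1 of the 3 values shown sits.

The unmeasured compound 4 `Cc1cc(C)c(S(=O)(=O)N2CCC(N3CCC(Cc4ccccc4)CC3)CC2)c(C)c1` differs from compound 1 by phenyl in place of hydrogen on a saturated chain carbon bound to a saturated ring carbon. Cut one bond further out, the change reads methyl to benzyl, so the 4-methylpiperidin-1-yl group of compound 1 carries a benzyl instead.

Among the compounds with values here, no measured step makes exactly this change. Within the data shown here, two steps bear on it indirectly. The step of an at least 160000-fold higher number from compound 1 to compound 2 (5.22 log units; beyond the scatter) shows that replacing the whole 4-methylpiperidin-1-yl group with phenyl removes all measurable activity. The step from compound 1 to compound 3 shows that exchanging 4-methylpiperidin-1-yl for 3,5-dimethylpiperidin-1-yl already costs a great deal. Both indicate narrow tolerance around this group, so enlarging it is expected to raise the number, though the piperidine itself is kept.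

Compound 4 is therefore estimated at 1.5 nM, within 0.08 nM to 60 nM. This expected step is a 50-fold higher number from compound 1 to compound 4 (1.70 log units; beyond the scatter).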

Compound 4, half-maximal inhibitory concentration: 3.5 nM
The estimate for compound 4 lay 2.3-fold (0.37 log units) below the measured number, and the stated range covers the measured number.
By their numbers in this assay, from the lowest: compound 1; then compound 4; then compound 3. At a limit, above all of these: compound 2.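

Lengthening the methyl of compound 1 to benzyl, with the piperidine kept, is the first change here made on the substituent itself rather than on the whole group, and in this assay it gives a 120-fold higher number from compound 1 to compound 4 (2.07 log units; beyond the scatter). The cost is large, yet compound 4 at 3.5 nM still gives a lower number than compound 3 at 17 nM, so an added phenyl on this saturated chain carbon costs less here than the move from 4-methylpiperidin-1-yl to 3,5-dimethylpiperidin-1-yl, and activity remains measurable. Nothing shown here explains why the benzyl costs this much or why activity survives it.

From the compounds shown here alone, whether the number climbs steadily as the methyl grows, as an ethyl or a propyl in its place would show, remains open. So does whether the aromatic ring of the benzyl matters in itself, which a cyclohexylmethyl group, or a benzyl carrying a fluorine or a hydroxyl on its ring, could begin to separate from the mere presence of a larger group.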